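From Ethoxy to Phenyl on the Shared Core

This account rests on a few compounds, and the source may have more. Where it says the series, first, only, none or still open, it means among the compounds named here.

In a functional assay on KB cells (Homo sapiens) for inhibition (on this read-out lower numbers stand for stronger inhibition and higher numbers for weaker inhibition), compound 3 `CCOCn1c(N)c(C#N)c2c(N)ncnc21` gives 138000 nM, the higher of the two true numbers in this small set. The nearest number is that of compound 2 `CCCn1c(N)c(C#N)c2c(N)ncnc21`, at 15000 nM. Ethoxy in place of ethyl gives a 9.2-fold higher number from compound 2 to compound 3 (0.96 log units; beyond the scatter).

Compound 1 `C=CCn1c(N)c(C#N)c2c(N)ncnc21` stands at > 100000 nM, which is a limit of the assay. Ethyl in place of vinyl gives an at least 6.6-fold lower number from compound 1 to compound 2 (0.82 log units; beyond the scatter), while ethoxy in place of vinyl gives a step that the limit leaves unreadable from compound 1 to compound 3.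

Compound 4 `N#Cc1c(N)n(Cc2ccccc2)c2ncnc(N)c12` differs from compound 3 by phenyl in place of ethoxy on a saturated chain carbon bound to an aromatic nitrogen. For the measured compounds named here, no measured step involves phenyl, so only the changes at this same place bear on it. Those steps were modest or larger, and compound 3 lies at the high end, so a modest fall is more likely than a further rise. The expected change is a 3.5-fold lower number from compound 3 to compound 4 (0.54 log units; beyond the scatter). For compound 4 the estimated value is 40000 nM, with an expected range from 8000 nM to 160000 nM.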

Compound 4, half-maximal inhibitory concentration: 34000 nM
Compound 4: middle estimate off by 1.2-fold (0.07 log units), on the high side; low and high end bracket the measured number.
By their numbers in this assay, from the lowest: compound 2; then compound 4; then compound 3.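

At the saturated chain carbon bound to an aromatic nitrogen, the set now holds a group with a six-membered aromatic ring, and in this assay the change from ethoxy to phenyl gives a 4.1-fold lower number from compound 3 to compound 4 (0.61 log units; beyond the scatter). Against ethyl the change runs the other way, with a 2.3-fold higher number from compound 2 to compound 4 (0.36 log units; beyond the scatter), so the number for phenyl falls between those for ethoxy and ethyl. Against vinyl the change gives an at least 2.9-fold lower number from compound 1 to compound 4 (0.46 log units; beyond the scatter); this step is a bound only, as the value it starts from, that of compound 1, is a limit of the assay: the limit of > 100000 nM in this assay, at which 1 of the 4 values shown sits.

On these data alone, whether a methoxy group or a chlorine atom on the phenyl ring, or a longer chain such as butyl, would shift the number further remains open. As far as these compounds go, it is also open whether the aromatic ring itself matters or only the larger group, and a cyclohexyl group at this place would speak to that.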